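Thiophene to pyridine swap in the hydroxyphenyl series

The compounds below may be only part of what the source reports. "The series", "measured", "known", "first", "only" and "open" are said of these compounds alone.

Three compounds of the series have numbers in an assay on isolated protein for inhibition of DNA topoisomerase 1 (Homo sapiens), with a stated time of 30 min, tested at 100 uM; a lower number here means a weaker effect, a higher number a stronger effect of the compound at the concentration tested. Compound 1 `Oc1cccc(-c2cc(-c3ccccc3)cc(-c3cccc(O)c3)n2)c1` gives 67.2% in this assay. Compound 2 `Oc1ccc(-c2cc(-c3ccccc3)cc(-c3ccc(O)cc3)n2)cc1` gives 0.3% in this assay. Compound 3 `Oc1cccc(-c2cc(-c3ccccc3)nc(-c3cccs3)c2)c1` gives 9.1% in this assay, which is the second highest of the three numbers; its nearest neighbour is compound 2, whose number is within the usual scatter of it, and its furthest is compound 1, whose number lies beyond the scatter above it. Among the measured compounds shown here, no pair of the measured compounds differs in a single place, so no measured step is available to size the change ahead.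

Compound 4 `Oc1cccc(-c2cc(-c3ccccc3)nc(-c3ccncc3)c2)c1` is the unmeasured compound. It differs from compound 3 as follows: pyridin-4-yl in place of thiophen-2-yl on an aromatic carbon. For the measured compounds named here, with no measured single-place step to lean on, a small step in this assay is expected from compound 3 to compound 4, a number 5.9 percentage points higher from compound 3 to compound 4 (within the scatter), in the upward direction but not clearly beyond the scatter. Compound 4 is therefore estimated at 15% in this assay, with a range from 0% to 45%.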

Compound 4, a percentage reported as inhibition, at one concentration (the size of the read-out at that concentration, not a potency): 60.8%
Beside the measured number, compound 4's estimate is 45.8 percentage points below it; measured number above the stated range.
By their numbers in this assay, from the lowest: compounds 2 and 3 (each within the scatter of the next); then compounds 4 and 1 (each within the scatter of the next).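

In this assay the series now has its first single-place step: pyridin-4-yl in place of thiophen-2-yl gives a number 51.7 percentage points higher from compound 3 to compound 4 (beyond the scatter) with the rest of the structure unchanged. The position next to the ring nitrogen therefore responds strongly to which aromatic ring it carries, even though both groups have the same counts of hydrogen-bond donors, hydrogen-bond acceptors and ring hetero atoms. Nothing measured here accounts for the size of this step.

Among the compounds shown here, the single swap changes ring size and hetero atom together, so the two remain unseparated; furan-2-yl, a five-membered ring with oxygen, and pyridin-3-yl, which moves the nitrogen within the six-membered ring, would begin to pull them apart. Also open, as far as these compounds go, is whether the step holds on a core carrying a 4-hydroxyphenyl group instead of the 3-hydroxyphenyl group.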